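A few compounds are considered here, and "the series" means these few. Any claim that something is new, unique, unknown or untested is made for them only; others in the source may bear on it.

Compound 1 `COc1ccccc1-c1nnc2sc(/C=C/c3ccco3)nn12` gives 78% in an assay for inhibition of histone-lysine N-methyltransferase, H3 lysine-79 specific (Homo sapiens), read by scintillation counting, with stated times of 15 min and 60 min, tested at 100 uM, in the presence of a further agent that is not named here; a lower number here means a weaker effect, a higher number a stronger effect of the compound at the concentration tested. Compound 2 `Fc1cccc(-c2nnc3sc(/C=C/c4ccco4)nn23)c1` gives 29% in this assay. Compound 3 `Cc1cccc(-c2nnc3sc(/C=C/c4ccco4)nn23)c1` gives 74% in this assay.

Compound 3 stands second highest of the three; compound 1 sits within the scatter of it, while compound 2 lies far lower. Compound 4 `C(=C/c1nn2c(-c3ccccc3)nnc2s1)\c1ccco1` differs from compound 3 by hydrogen in place of methyl on an aromatic carbon. Among the compounds with values here, the one measured step at this place, a number 45 percentage points higher from compound 2 to compound 3 (beyond the scatter), shows that exchanging the group there can move the read-out strongly. Hydrogen matches neither fluoro nor methyl, so no direct comparison exists. Going to compound 4, the number is expected to move by a number 14 percentage points lower from compound 3 to compound 4 (beyond the scatter), a moderate loss. Compound 4 is therefore estimated at 60%, within 38% to 82%.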

Compound 4, a percentage reported as inhibition, at one concentration (the size of the read-out at that concentration, not a potency): 81%
For compound 4 the middle estimate is 21 percentage points below the measured one; low and high end bracket the measured number.
By their numbers in this assay, from the lowest: compound 2; then compounds 3, 1 and 4 (each within the scatter of the next).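

The bare phenyl ring of compound 4 shows that this ring needs no added group for a high read-out: hydrogen for methyl gives a number 7 percentage points higher from compound 3 to compound 4 (within the scatter) and hydrogen for methoxy gives a number 3 percentage points higher from compound 1 to compound 4 (within the scatter). Hydrogen for fluoro gives a number 52 percentage points higher from compound 2 to compound 4 (beyond the scatter), so among the groups shown only fluoro goes with a low number. Nothing measured here explains this difference.

On these data alone, what an amine or a carboxylic acid on this ring would do stays open. So does whether fluoro elsewhere on the ring would give the same low number.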